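The source may hold more compounds than are shown below. What is called first, only, known or untested is meant among the compounds shown, and "the series" means these compounds.

Of the compounds shown here, two sharing a common core have been measured so far in a toxicity assay on MRC5 cells (Homo sapiens) for cytotoxicity, read by MTT assay, with a stated time of 72 h; on this read-out lower numbers stand for an effect already at smaller amounts and higher numbers for an effect only at larger amounts of compound: compound 1 `Cn1cc(/C=N/NC(N)=S)c2ccccc21` and compound 2 `Cc1ccc(/C=N/NC(N)=S)c2ccccc12`. Compound 1 gives only a limit of the assay, > 200000 nM, in this assay. Among the measured compounds shown here, compound 2 gives 37000 nM in this assay and is thus the only compound with a numerical reading. The value of compound 1 sits instead at a limit of the assay, (the limit of > 200000 nM in this assay, at which 1 of the 2 values shown sits). Compound 3 `COc1ccc(/C=N/NC(N)=S)c2ccccc12` has not yet been measured. It differs from compound 2 in one place, (methoxy in place of methyl on an aromatic carbon), in words methoxy in place of methyl on an aromatic carbon. For the measured compounds named here, no measured pair shows what such a change does within this set. The step from compound 2 to compound 3 in this assay is expected to be a 1.1-fold higher number from compound 2 to compound 3 (0.03 log units; within the scatter), a shift no larger than the usual scatter, with no clear direction. Compound 3 is therefore estimated at 40000 nM in this assay, with a likely range from 15000 nM to 150000 nM.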

Compound 3, half-maximal effective concentration: 42000 nM
For compound 3 the middle estimate is 1.1-fold (0.02 log units) below the measured one; low and high end bracket the measured number.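

Within this assay the set now holds its first pair differing in one place, and methoxy in place of methyl on an aromatic carbon gives a 1.1-fold higher number from compound 2 to compound 3 (0.06 log units; within the scatter) at this position, para to a group of 6 heavy atoms. Among the compounds shown here, this change, which brings in one hydrogen-bond acceptor, leaves the two compounds within the scatter of each other here, something the earlier compounds could not show. No measured property shown bears on this result.

Going by these compounds, whether another group at this position, such as an amine, a carboxylic acid or a longer chain, would give a reading beyond the scatter from compound 2 remains open. On these data alone, it is also open whether the same exchange on another aromatic carbon of the shared core would give a similar step.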